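Estimating Lipophilicity After Growing Methyl to Propyl

This account rests on a few compounds, and the source may have more. Where it says the series, first, only, none or still open, it means among the compounds named here.

Compound 1, `Cc1nc2ccccc2c(=O)n1/N=C/c1ccc(Oc2ccc(Br)cc2)cc1`: 4.64
Compound 2, `Cc1nc2ccccc2c(=O)n1/N=C/c1ccc(Oc2ccccc2)cc1`: 4.01
Compound 3, `Cc1cc(Oc2ccc(/C=N/n3c(C)nc4ccccc4c3=O)cc2)ccc1Cl`: 4.41

In a physicochemical assay for lipophilicity, in phosphate buffer, measured as octanol-water partition (a lower number here means a more polar compound, a higher number a more lipophilic compound), compound 2 gives 4.01, the lowest of the three numbers. The step of a number 0.40 log units higher from compound 2 to compound 3 (beyond the scatter) and the step of a number 0.63 log units lower from compound 1 to compound 2 (beyond the scatter) both lie beyond the scatter, while the step of a number 0.23 log units lower from compound 1 to compound 3 (within the scatter) does not. All three measured steps alter the ring on the ether oxygen and leave the rest of the shared core untouched.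

Compound 4, `CCCc1nc2ccccc2c(=O)n1/N=C/c1ccc(Oc2ccccc2)cc1`, differs from compound 2 by ethyl in place of hydrogen on a saturated chain carbon bound to an aromatic carbon. Going by the values given here, no measured step touches this position, so the expectation rests only on the size of the steps seen elsewhere: adding chloro and methyl to the ether ring gave the modest rise a number 0.40 log units higher from compound 2 to compound 3 (beyond the scatter), and a bromo alone gave the rise seen in reverse as a number 0.63 log units lower from compound 1 to compound 2 (beyond the scatter). Two added carbons on the chain are therefore expected to move compound 4 upward by a modest to moderate amount, a number 0.79 log units higher from compound 2 to compound 4 (beyond the scatter).

Compound 4 is estimated at 4.8, with a range of 4.4 to 5.3.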

Compound 4, partition coefficient: 5.2
Estimate against measurement, compound 4: 0.40 log units below; measured number inside the range.
By their numbers in this assay, from the lowest: compound 2; then compounds 3 and 1 (each within the scatter of the next); then compound 4.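

In this assay, ethyl in place of hydrogen on a saturated chain carbon bound to an aromatic carbon, which turns methyl to propyl, gives a number 1.19 log units higher from compound 2 to compound 4 (beyond the scatter), the first step shown away from the ring on the ether oxygen. This large step exceeds the two changes on that ring, a number 0.40 log units higher from compound 2 to compound 3 (beyond the scatter) and a number 0.63 log units lower from compound 1 to compound 2 (beyond the scatter), so among the compounds shown the chain position carries the biggest move in the number. Nothing on hand accounts for the size of this step.

The compounds shown leave open how the number runs along the chain, which an ethyl or a longer chain at this position would show, and what an amine or a carboxylic acid on the chain would do. From the compounds shown here alone, whether the same step holds with bromo on the ether ring also remains open.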